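A Second Chloro on the Aryl Ring of Compound 2

The source may hold more compounds than are shown below. What is called first, only, known or untested is meant among the compounds shown, and "the series" means these compounds.

In an assay on cells for displacement of a labelled ligand from adenosine receptor A1 (Homo sapiens), read by scintillation counting and radioligand binding, with a stated time of 60 min (a higher number here means a weaker inhibitor, a lower number a stronger inhibitor), compound 2 `CN1CCN(c2nc(-c3cccc(Cl)c3)nc3[nH]cnc23)CC1` gives 79.4 nM, the highest of the three measured numbers. Compound 1 `Clc1cccc(-c2nc(N3CCCCC3)c3nc[nH]c3n2)c1` gives 50.1 nM, and the step of a 1.6-fold higher number from compound 1 to compound 2 (0.20 log units; within the scatter) lies within the scatter. Among the compounds with values here, compound 3 `Oc1ccc(-c2nc(N3CCCCC3)c3nc[nH]c3n2)cc1` gives 10 nM, and the step of a 5.0-fold lower number from compound 1 to compound 3 (0.70 log units; beyond the scatter) is the only measured change beyond the scatter. Compound 4 `CN1CCN(c2nc(-c3cc(Cl)ccc3Cl)nc3[nH]cnc23)CC1` differs from compound 2 by chloro in place of hydrogen on an aromatic carbon. Within the data shown here, no measured step adds a chloro group to an aryl ring that already carries one, so none bears directly on this change; the one aryl-ring step exchanges the whole group rather than adding to it. The expected step is therefore a 1.3-fold higher number from compound 2 to compound 4 (0.10 log units; within the scatter), within the scatter. Compound 4 is estimated at 100 nM, in a range from 30 nM to 320 nM.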

Compound 4, inhibition constant: 2510 nM
Estimate against measurement, compound 4: 25-fold (1.40 log units) below; measured number outside the range, above it.
By their numbers in this assay, from the lowest: compound 3; then compounds 1 and 2 (each within the scatter of the next); then compound 4.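

Adding one chloro group to the aryl ring, on the carbon ortho to a large group and para to a chloro group, gives a 32-fold higher number from compound 2 to compound 4 (1.50 log units; beyond the scatter). So in this assay a single added atom at this position changes the number far more than any earlier step did. The data shown give no explanation for this loss.

From the compounds shown here alone, whether it belongs to chloro itself or to any group on this carbon remains open, as a fluoro or methyl group there could tell. Also open, going by these compounds, is whether the same addition costs as much with piperidin-1-yl in place of 4-methylpiperazin-1-yl.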